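This account rests on a few compounds, and the source may have more. Where it says the series, first, only, none or still open, it means among the compounds named here.

In a functional assay on L1210 cells (Mus musculus) for inhibition (a higher number here means a weaker inhibitor, a lower number a stronger inhibitor), compound 1 `Nc1ccn(C/C=C/CO)c(=O)n1` gives > 550000 nM, which is a limit and not a number. Compound 2 `Nc1ccn(C/C=C\CCl)c(=O)n1` reads 10000 nM, the lower of the two actual numbers in the series. Compound 3 `Nc1ncnc2c1ncn2CC#CCO` reads 490000 nM. Compound 4 `Nc1ccn(CC#CCO)c(=O)n1` is still unmeasured. It differs from compound 2 as follows: 3-hydroxyprop-1-yn-1-yl in place of 3-chloroprop-1-en-1-yl on a saturated chain carbon bound to an aromatic nitrogen. In words, this puts 3-hydroxyprop-1-yn-1-yl in place of 3-chloroprop-1-en-1-yl on a saturated chain carbon bound to an aromatic nitrogen.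

Among the measured compounds shown here, one measured step bears on this: an at least 55-fold lower number from compound 1 to compound 2 (1.74 log units; beyond the scatter). It is large and beyond the scatter. The change to compound 4 runs the opposite way, from the chloro chain back to a hydroxy chain, though with a triple bond in place of the double bond. Compound 3 carries the same 3-hydroxyprop-1-yn-1-yl on a different core and sits at 490000 nM. A large step to a higher number is therefore expected in this assay, estimated as a 40-fold higher number from compound 2 to compound 4 (1.60 log units; beyond the scatter). The expected value for compound 4 is 400000 nM, with an estimated range of 150000 nM to 900000 nM.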

Compound 4, half-maximal inhibitory concentration: > 550000 nM
Compound 4 gave a limit, no number; the forecaster's own chance of this, stated with the estimate: 45%; middle value at least 1.3-fold (0.13 log units) from the limit.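

In this assay, with the shared core held fixed, 3-hydroxyprop-1-yn-1-yl in place of 3-chloroprop-1-en-1-yl on a saturated chain carbon bound to an aromatic nitrogen gives an at least 55-fold higher number from compound 2 to compound 4 (1.74 log units; beyond the scatter). Compound 4 reads > 550000 nM, which is a limit and not a number, and the step between compound 1 and compound 4 cannot be read: the limit of > 550000 nM in this assay, at which 2 of the 4 values shown sit. On this core, then, both hydroxy chains, with a double or a triple bond, end at the limit, and only the chloro chain of compound 2 gives an actual number.

The step from compound 2 to compound 4 changes the chain's end group and its bond together, so the two contributions stay unseparated. From the compounds shown here alone, whether 3-chloroprop-1-yn-1-yl, 3-bromoprop-1-en-1-yl or 3-aminoprop-1-en-1-yl chains would read near compound 2 remains open.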